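This account rests on a few compounds, and the source may have more. Where it says the series, first, only, none or still open, it means among the compounds named here.

Compound 1 `COc1ccc2nc(C)cc(OCC(=O)Nc3cc(C)cc(C)c3)c2c1` was examined in a toxicity assay on HepG2 cells (Homo sapiens) for inhibition, read by CellTiter-Glo, with a stated time of 48 h (on this read-out higher numbers stand for weaker inhibition and lower numbers for stronger inhibition), where compound 1 gives 20000 nM. Among the three compounds measured, compound 1 holds the second highest number. Its nearest neighbour is compound 2 `Cc1cc(C)cc(NC(=O)COc2cc(C)nc3ccc(C)cc23)c1`, for which this assay gives 15900 nM, and the step of a 1.3-fold lower number from compound 1 to compound 2 (0.10 log units; within the scatter), a methyl in place of methoxy on an aromatic carbon. Furthest away is compound 3 `CCC(Oc1cc(C)nc2ccc(OC)cc12)C(=O)Nc1cc(C)cc(C)c1`, which in this assay gives 79400 nM; the step of a 4.0-fold higher number from compound 1 to compound 3 (0.60 log units; beyond the scatter), an ethyl in place of hydrogen on the chain carbon.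

Compound 4 `COc1ccc2nc(C)cc(OCC(=O)Nc3cccc(C)c3)c2c1` has not yet been measured. It differs from compound 1 by hydrogen in place of methyl on an aromatic carbon, so that the 3,5-dimethylphenyl becomes 3-methylphenyl. The step most like it is the small aromatic change from compound 1 to compound 2, which stayed within the scatter; the chain change to compound 3 is of another kind. For compound 4 in this assay the step of a 1.1-fold higher number from compound 1 to compound 4 (0.04 log units; within the scatter) is therefore expected to stay within the scatter. Compound 4 is estimated at 22000 nM, in the range 10000 nM to 50000 nM.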

Compound 4, half-maximal inhibitory concentration: 39800 nM
Compound 4: the middle estimate sits 1.8-fold (0.26 log units) below what was measured; the measured number falls inside the stated range.
By their numbers in this assay, from the lowest: compounds 2, 1, 4 and 3 (each within the scatter of the next, the first and the last beyond it).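

Among these compounds, the first two compounds left the 3,5-dimethylphenyl untouched, and compound 4 is the first to alter it: with hydrogen in place of methyl on an aromatic carbon of that ring, this assay gives a 2.0-fold higher number from compound 1 to compound 4 (0.30 log units; within the scatter). The change to 3-methylphenyl is therefore not resolved by this read-out, even though the printed step is larger than a 1.3-fold lower number from compound 1 to compound 2 (0.10 log units; within the scatter), which also stays within the scatter. Among the single changes from compound 1, only the ethyl on the chain carbon, in compound 3, goes beyond the scatter, and no independent observation bears on this result.

From the compounds shown here alone, whether the remaining methyl could also give way to hydrogen, leaving a plain phenyl, stays open. So does what a chlorine, a methoxy or an amine would give on this ring.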